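The compounds below may be only part of what the source reports. "The series", "measured", "known", "first", "only" and "open" are said of these compounds alone.

Compound 1 `CC(C)S(=O)(=O)N1CCc2nc(C#Cc3ccccc3)sc2C1` and compound 3 `O=S(=O)(C1CCCCC1)N1CCc2nc(C#Cc3ccccc3)sc2C1` share one core and differ in a single place: cyclohexyl in place of isopropyl on a sulfonyl sulfur. In an assay on HEK293 cells for negative allosteric modulation of metabotropic glutamate receptor 5 (Homo sapiens), read by FLIPR, with a stated time of 1 h (on this read-out lower numbers stand for stronger inhibition and higher numbers for weaker inhibition), compound 1 gives 11 nM, while compound 3 gives 480 nM, so that a 44-fold higher number from compound 1 to compound 3 (1.64 log units; beyond the scatter). Compound 2 `CC(C)S(=O)(=O)N1Cc2nc(C#Cc3ccccc3)sc2C1` carries a different core; the difference between the two cores is not broken down here. In this assay compound 2 gives 140 nM. Compound 4 `O=S(=O)(C1CCCCC1)N1Cc2nc(C#Cc3ccccc3)sc2C1` is obtained from compound 2 by the same change: cyclohexyl in place of isopropyl on a sulfonyl sulfur. Since the change sits at an identical place in both pairs, the new step is expected to resemble the earlier one, although the different core adds uncertainty. The step from compound 2 to compound 4 is estimated at a 21-fold higher number from compound 2 to compound 4 (1.33 log units; beyond the scatter) because the earlier step was a 44-fold higher number from compound 1 to compound 3 (1.64 log units; beyond the scatter). Compound 4 is therefore expected to give about 3000 nM, plausibly between 800 nM and 12000 nM.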

Compound 4, half-maximal inhibitory concentration: > 10000 nM
Compound 4: only a limit was reported; the forecaster's own chance of this, stated with the estimate: 15%; middle value at least 3.3-fold (0.52 log units) away from the limit.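

In this assay compound 4 gives > 10000 nM, which is a limit of the assay and not a number. Cyclohexyl in place of isopropyl on a sulfonyl sulfur again weakens inhibition, an at least 71-fold higher number from compound 2 to compound 4 (1.85 log units; beyond the scatter), so the direction of the change carries over, while its exact size on this core stays unknown: the same change on two cores in this assay, a 44-fold higher number (1.64 log units; beyond the scatter) from compound 1 to compound 3 and an at least 71-fold higher number (1.85 log units; beyond the scatter) from compound 2 to compound 4; the limit leaves it open whether they differ. Two cores are a small sample, and they set no rule for any other core in this series.

The compounds shown leave open whether the ring of cyclohexyl or simply its larger number of carbon atoms drives the loss. A cyclopropyl group or an open hexyl chain on the sulfonyl sulfur could separate the two.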